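A few compounds are considered here, and "the series" means these few. Any claim that something is new, unique, unknown or untested is made for them only; others in the source may bear on it.

Of the compounds shown here, three built on one shared core have been measured so far. Compound 1 `Cc1cc(C(=O)O)c(C)n1-c1cccc(F)c1` carries a fluoro on an aromatic carbon of its outer six-membered ring, compound 2 `Cc1cc(C(=O)O)c(C)n1-c1ccc(C(F)(F)F)c(Cl)c1` carries a trifluoromethyl together with a chloro, and compound 3 `Cc1cccc(-n2c(C)cc(C(=O)O)c2C)c1` carries a methyl. In an assay on cells for inhibition of Palmitoleoyl-protein carboxylesterase NOTUM variant C330S (Homo sapiens), read by fluorescence, with a stated time of 40 min (a lower number here means a stronger inhibitor, a higher number a weaker inhibitor), compound 1 gives 1500 nM. In this assay compound 2 gives 1500 nM. In this assay compound 3 gives 1500 nM.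

Compound 3 therefore stands level with both neighbours. For the measured compounds named here, the step of no change at the digits printed from compound 1 to compound 3 (within the scatter) shows that exchanging fluoro for methyl left the read-out where it was, and compound 2, which differs from compound 3 in more than one place, sits at the same number, so no single step is drawn between those two.

Compound 4 `Cc1cc(C(=O)O)c(C)n1-c1cccc(Cl)c1` is the next member. It differs from compound 3 by chloro in place of methyl on an aromatic carbon. Going by the values given here, the only single step that bears on this exchange is no change at the digits printed from compound 1 to compound 3 (within the scatter), which was flat, and compound 2, bearing a chloro alongside a trifluoromethyl, also gives the same number as compound 3. The step of no change at the digits printed from compound 3 to compound 4 (within the scatter) is accordingly expected to stay within the scatter. Compound 4 is estimated at 1500 nM, with a range from 700 nM to 3200 nM.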

Compound 4, half-maximal inhibitory concentration: 430 nM
Compound 4: the middle estimate sits 3.5-fold (0.54 log units) above what was measured; measured number below the stated range.
By their numbers in this assay, from the lowest: compound 4; then compounds 1, 2 and 3 (each within the scatter of the next).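

In this assay, chloro on this aromatic carbon gives a result that fluoro and methyl did not: the exchange for methyl is a real step (a 3.5-fold lower number from compound 3 to compound 4 (0.54 log units; beyond the scatter)), and so is the exchange for fluoro (a 3.5-fold lower number from compound 1 to compound 4 (0.54 log units; beyond the scatter)), whereas the earlier exchange of fluoro for methyl was flat (no change at the digits printed from compound 1 to compound 3 (within the scatter)). The position is therefore not indifferent to its substituent, although the change is modest in size. The trifluoromethyl matters as well, since hydrogen in its place, with the chloro kept, also lowers the number (a 3.5-fold lower number from compound 2 to compound 4 (0.54 log units; beyond the scatter)), so chloro on this carbon shows its lower number only in the compound without the trifluoromethyl. Nothing available here explains why chloro differs from fluoro and methyl, or why the trifluoromethyl cancels the difference.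

From the compounds shown here alone, whether a bromo or a methoxy on this same carbon would go lower still remains open, as does the effect of moving the chloro to another carbon of the ring. The compounds shown also all keep the carboxylic acid, so they leave open what an amide in its place would do.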